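A chlorophenyl swap at a cytotoxicity limit

A few compounds are considered here, and "the series" means these few. Any claim that something is new, unique, unknown or untested is made for them only; others in the source may bear on it.

Values in an ADME assay on HCT-116 cells (Homo sapiens) for cytotoxicity, read by CellTiter-Glo, with a stated time of 72 h (a higher number here means a weaker inhibitor, a lower number a stronger inhibitor), each one a limit:
- compound 1 `COc1ccccc1-c1ccc(S(=O)(=O)N2CCC(N3CCC(C)CC3)CC2)cc1`: > 5000 nM
- compound 2 `CC1CCN(C2CCN(S(=O)(=O)c3ccc(-c4ccccc4F)cc3)CC2)CC1`: > 5000 nM
- compound 3 `CCCOc1ccc(S(=O)(=O)N2CCC(N3CCC(C)CC3)CC2)cc1`: > 5000 nM

Compound 3 therefore stands at a limit, with no exact number. The move to compound 4 `CC1CCN(C2CCN(S(=O)(=O)c3ccc(-c4ccc(Cl)cc4)cc3)CC2)CC1` is 4-chlorophenyl in place of propoxy on an aromatic carbon: 4-chlorophenyl in place of propoxy, para to a large group.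

The nearest measured changes replace 2-methoxyphenyl or 2-fluorophenyl with propoxy: a step that the two limits leave unreadable from compound 1 to compound 3 and a step that the two limits leave unreadable from compound 2 to compound 3. Neither gives a size to carry over. Compound 2, with 2-fluorophenyl in that place, also gives a limit, > 5000 nM.

Another limit in this assay is the likeliest result, so the expected step, a step that the limit leaves unreadable from compound 3 to compound 4, has no clear direction. Compound 4 is estimated at 7000 nM, within an expected range of 3000 nM to 15000 nM.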

Compound 4, half-maximal inhibitory concentration: > 5000 nM
Compound 4: only a limit was reported; the forecaster's own chance of this, stated with the estimate: 75%; the middle value does not contradict the limit.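

No step to compound 4 from compound 1, compound 2 or compound 3 can be read, because all four compounds end at the same limit: the limit of > 5000 nM in this assay, at which 4 of the 4 values shown sit.

The compounds shown leave open whether exchanging these groups changes cytotoxicity at all.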